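The source may report more compounds than this note shows. Statements on the series, on what has been measured and on what is new or still open speak of the compounds shown alone.

Measured in a functional assay on KB cells (Homo sapiens) for antiproliferative activity, read by sulforhodamine B assay, with a stated time of 72 h; on this read-out lower numbers stand for stronger inhibition and higher numbers for weaker inhibition:
- Compound 1 `COc1ccc(/C=C2\CCC=CC2=O)cc1OC`: 900 nM
- Compound 2 `COc1cc(/C=C2\CCC=CC2=O)cc(OC)c1`: 3630 nM
- Compound 3 `COc1cc(/C=C2\CCC=CC2=O)cc(OC)c1OC`: 880 nM

Compound 3 stands at the low end of these numbers, level with compound 1 and clear of compound 2. The two measured steps are a 1.0-fold lower number from compound 1 to compound 3 (0.01 log units; within the scatter) and a 4.1-fold lower number from compound 2 to compound 3 (0.62 log units; beyond the scatter).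

Compound 4 `COc1cc(/C=C2\CCC=C(I)C2=O)cc(OC)c1OC` differs from compound 3 by one change: iodo in place of hydrogen on a double-bonded ring carbon. Both measured steps are methoxy in place of hydrogen on an aromatic carbon, so neither tests this change. They show only how large steps in this series have been. No direction follows from them, and no shift beyond the scatter is expected in this assay.

The estimate means a 1.8-fold lower number from compound 3 to compound 4 (0.25 log units; within the scatter).

Compound 4 is expected at 500 nM, with an estimated range of 120 nM to 2000 nM.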

Compound 4, half-maximal inhibitory concentration: 3670 nM
Estimate against measurement, compound 4: 7.3-fold (0.87 log units) below; the measured number lies above the stated range.
By their numbers in this assay, from the lowest: compounds 3 and 1 (each within the scatter of the next); then compounds 2 and 4 (each within the scatter of the next).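

In this assay the change of iodo in place of hydrogen on a double-bonded ring carbon gives a 4.2-fold higher number from compound 3 to compound 4 (0.62 log units; beyond the scatter) and so weakens inhibition beyond the scatter. This shows that the non-aromatic ring responds to substitution at this carbon, which the methoxy steps on the aromatic carbons could not show. Nothing available explains this shift.

The compounds shown leave open whether the loss belongs to iodo alone or to any group on this carbon. A chloro, a methyl or an amine in the same place could behave differently.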